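The compounds below may be only part of what the source reports. "The series", "measured", "known", "first", "only" and "open" are said of these compounds alone.

In a functional assay on MDA-MB-231 cells (Homo sapiens) for inhibition, read by sulforhodamine B assay (on this read-out lower numbers stand for stronger inhibition and higher numbers for weaker inhibition), compound 1 (`COC(=O)CC/C(C)=C/Cc1c(OC)c(C)c2c(c1OCC#CCN1CCN(Cc3ccc(Cl)cc3)CC1)C(=O)OC2`) gives > 50000 nM, which is a limit of the assay and not a number. Compound 2 (`COC(=O)CC/C(C)=C/Cc1c(OC)c(C)c2c(c1OCC#CCN1CCCc3ccccc31)C(=O)OC2`) gives > 50000 nM, which is also a limit. This places compound 2 at the limit of > 50000 nM in this assay, at which 2 of the 2 values shown sit. Compound 3 (`CCCCNc1ccc(CC#CCOc2c(C/C=C(\C)CCC(=O)OC)c(OC)c(C)c3c2C(=O)OC3)cc1`) carries 4-(butylamino)phenyl in place of 1,2,3,4-tetrahydroquinolin-1-yl on a saturated chain carbon bound to a triple-bonded carbon. Going by the values given here, with no measured step to guide it, the expectation in this assay is no change beyond the usual scatter, an estimated at least 1.2-fold lower number from compound 2 to compound 3 (0.09 log units; that floor lies within the scatter). For compound 3 the expected value is 40000 nM, within an estimated range of 12000 nM to 60000 nM.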

Compound 3, half-maximal inhibitory concentration: 19800 nM
Beside the measured number, compound 3's estimate is 2.0-fold (0.31 log units) above it, within the range that was stated.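

Swapping in 4-(butylamino)phenyl for 1,2,3,4-tetrahydroquinolin-1-yl on a saturated chain carbon bound to a triple-bonded carbon gives, in this assay, an at least 2.5-fold lower number from compound 2 to compound 3 (0.40 log units; beyond the scatter). This shows that the group at this position can change the read-out, although this single step cannot tell which part of the change matters. Until now, the values shown were limits of the assay and not numbers, so no step could be read: the limit of > 50000 nM in this assay, at which 2 of the 3 values shown sit.

As far as these compounds go, the full size of the step remains open. So does the role of the butyl chain, which a plain 4-aminophenyl group or an octyl chain on that nitrogen would help to test.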